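Methyl Returns to the Carboxyphenyl Ring

A few compounds are considered here, and "the series" means these few. Any claim that something is new, unique, unknown or untested is made for them only; others in the source may bear on it.

Going by the values given here, compound 2 `Cc1c(OCCCCOc2ccc(C(=O)O)cc2)ccc(C(=O)CC(C)C)c1O` gives 122 nM in an assay on HEK293 cells for positive allosteric modulation of metabotropic glutamate receptor 2 (Rattus norvegicus), read by thallium flux, with a stated time of 2.5 min (a lower number here means that less compound is needed, a higher number that more compound is needed for the effect), the highest of the two numbers so far; its nearest neighbour is compound 1 `COc1cc(C(=O)O)ccc1OCCCCOc1ccc(C(=O)CC(C)C)c(O)c1C`, which gives 40 nM. Among the compounds with values here, the single measured step, a 3.1-fold higher number from compound 1 to compound 2 (0.48 log units; beyond the scatter), puts hydrogen in place of methoxy on an aromatic carbon, and the number rises. Compound 3 `Cc1ccc(C(=O)O)cc1OCCCCOc1ccc(C(=O)CC(C)C)c(O)c1C` has not yet been measured. Its change from compound 2 is 5-carboxy-2-methylphenyl in place of 4-carboxyphenyl on an oxygen on a saturated carbon. Within the data shown here, a substituent is thus added back to the carboxyphenyl ring that was stripped in the step from compound 1 to compound 2, so that step is the one that bears on the case; but a methyl is not a methoxy, and no measured pair compares the two. Compound 3 is therefore expected to show a modest step of a 2.0-fold lower number from compound 2 to compound 3 (0.31 log units; beyond the scatter), with an estimated 60 nM and a range from 25 nM to 150 nM.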

Compound 3, half-maximal effective concentration: 454 nM
Estimate against measurement, compound 3: 7.6-fold (0.88 log units) below; the measured number lies above the stated range.
By their numbers in this assay, from the lowest: compound 1; then compound 2; then compound 3.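

In this assay, the swap on the oxygen gives a 3.7-fold higher number from compound 2 to compound 3 (0.57 log units; beyond the scatter), so the number goes up rather than down, and a larger substituted ring at this place does not by itself bring back the lower number of compound 1. The two group names show that this single step holds two differences: a methyl enters, and the carboxy label moves from 4 to 5, so the rise cannot be assigned to either one alone. No measurement available here explains the rise.

Still open, on these data alone, is which of the two differences carries the effect: 3-carboxyphenyl would test the moved carboxylic acid alone, and 4-carboxy-2-methylphenyl the added methyl alone. Whether a methyl and a methoxy differ when the carboxylic acid stays in one place also remains unsettled.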